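The compounds below may be only part of what the source reports. "The series", "measured", "known", "first", "only" and "open" are said of these compounds alone.

Compound 1 `C[C@]1(C(=O)N2CC[C@](c3ccc(C(F)(C(F)(F)F)C(F)(F)F)cc3)(S(=O)(=O)c3ccc(F)cc3)C2)CC[C@@H](C(=O)O)CC1`: 85%.
Compound 2 `O=C(O)C12CCC(C(=O)N3CC[C@](c4ccc(C(F)(C(F)(F)F)C(F)(F)F)cc4)(S(=O)(=O)c4ccc(F)cc4)C3)(CC1)C2`: "not determined" (no result reported).

In an ADME assay on microsomes from liver (Homo sapiens) for metabolic stability, with a stated time of 10 min (on this read-out lower numbers stand for a less stable compound and higher numbers for a more stable compound), compound 1 gives 85%, the only number shown here, so it stands alone and cannot be ranked; in this assay compound 2 gives "not determined" (no result reported). Compound 3 `CCC1(C(=O)N2CC[C@](c3ccc(C(F)(C(F)(F)F)C(F)(F)F)cc3)(S(=O)(=O)c3ccc(F)cc3)C2)CCS(=O)(=O)CC1` differs from compound 1 in one place: 4-ethyl-1,1-dioxothian-4-yl in place of 4-carboxy-1-methylcyclohexyl on a carbonyl carbon. Going by the values given here, no step between two measured compounds is available to set a scale, so the size of this move is uncertain. A modest decrease in this assay, possibly just beyond the usual scatter, is expected; the estimated step reads a number 13 percentage points lower from compound 1 to compound 3 (beyond the scatter). Compound 3 is expected to give 72%, in a range from 50% to 92%.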

Compound 3, percent of the compound remaining: 3%
Beside the measured number, compound 3's estimate is 69 percentage points above it; measured number outside the range, below it.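

In this assay, putting 4-ethyl-1,1-dioxothian-4-yl in place of 4-carboxy-1-methylcyclohexyl on a carbonyl carbon gives a number 82 percentage points lower from compound 1 to compound 3 (beyond the scatter). The read-out is therefore very sensitive to what sits at this position, even though both groups hold the same number of heavy atoms. Nothing measured here explains the fall.

As far as these compounds go, this swap changes the ring, the carboxylic acid and the alkyl chain together, so the part responsible stays open. Also open, from the compounds shown here alone, is how 4-carboxy-1-ethylcyclohexyl, or an amine in place of the carboxylic acid, would read.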